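A methoxy group added to compound 3: the expected shift

The compounds below may be only part of what the source reports. "The series", "measured", "known", "first", "only" and "open" are said of these compounds alone.

Three ureas built on one shared core have been examined in an assay on isolated protein for inhibition of Ephrin type-A receptor 2 (Homo sapiens), read by thermal shift assay, tested at 10 uM; on this read-out higher numbers stand for stronger stabilisation of the target against heat and lower numbers for weaker stabilisation of the target. Compound 1 `CCOc1ccc(NC(=O)Nc2cc(C(C)(C)C)nn2-c2ccccc2)cc1` gives 1 degrees C in this assay. Compound 2 `Cc1cc(C)cc(NC(=O)Nc2cc(C(C)(C)C)nn2-c2ccccc2)c1` gives 0.7 degrees C. Compound 3 `CC(C)(C)c1cc(NC(=O)Nc2ccccc2)n(-c2ccccc2)n1` gives 1.6 degrees C, the highest of the three numbers, yet its steps from the other two, a number 0.60 degrees C higher from compound 1 to compound 3 (within the scatter) and a number 0.90 degrees C higher from compound 2 to compound 3 (within the scatter), both lie within the scatter, as does the step of a number 0.30 degrees C lower from compound 1 to compound 2 (within the scatter). On these numbers, then, compound 3 stands at the top only nominally, with no separation from its neighbours that the assay can resolve.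

Compound 4 `COc1cccc(NC(=O)Nc2cc(C(C)(C)C)nn2-c2ccccc2)c1` differs from compound 3 by methoxy in place of hydrogen on an aromatic carbon. Two measured steps speak to this change, since both alter the same phenyl ring: the removal of an ethoxy in a number 0.60 degrees C higher from compound 1 to compound 3 (within the scatter) and the removal of two methyls in a number 0.90 degrees C higher from compound 2 to compound 3 (within the scatter). Neither moved the melting temperature beyond the scatter, so putting a methoxy onto that ring is expected to leave this assay essentially unchanged, with no step in either direction beyond the scatter, the expected step being a number 0.30 degrees C lower from compound 3 to compound 4 (within the scatter). Compound 4 is therefore estimated to give 1.3 degrees C, within a range from 0.3 degrees C to 2.3 degrees C.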

Compound 4, shift of the target's melting temperature: 1.8 degrees C
The estimate for compound 4 lay 0.50 degrees C below the measured number; the measured number falls inside the stated range.
By their numbers in this assay, from the lowest: compounds 2, 1, 3 and 4 (each within the scatter of the next, the first and the last beyond it).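

In this assay, within the data shown here, adding a group to the unsubstituted phenyl ring of compound 3 gives a number 0.20 degrees C higher from compound 3 to compound 4 (within the scatter) and so leaves methoxy on this aromatic carbon unresolved from hydrogen, a direct comparison that the earlier steps, which only removed other groups, did not offer. Among these compounds, changing the substituents on this ring also produces the first step beyond the scatter, with 3-methoxyphenyl in place of 3,5-dimethylphenyl giving a number 1.1 degrees C higher from compound 2 to compound 4 (beyond the scatter) in a modest move, while 3-methoxyphenyl in place of 4-ethoxyphenyl gives a number 0.80 degrees C higher from compound 1 to compound 4 (within the scatter) and remains unresolved. Nothing measured here accounts for these numbers.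

From the compounds shown here alone, whether a methoxy on another carbon of this ring would read the same stays open, as does the effect of an amine or a carboxylic acid on the same aromatic carbon. Going by these compounds, all four compounds keep the rest of the shared core unchanged, so how this read-out would respond to a longer chain elsewhere on the core also remains unknown.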